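The source may hold more compounds than are shown below. What is called first, only, known or untested is meant among the compounds shown, and "the series" means these compounds.

Working notes on a series of ester-bearing amides sharing one core, tested for cytotoxicity in a functional assay on A549 cells (Homo sapiens) for cytotoxicity, read by MTT assay, with a stated time of 24 h, tested at 80 uM; on this read-out higher numbers stand for a weaker effect at the one concentration tested and lower numbers for a stronger effect.

Compound 1 `CCCCCCCCOC(=O)CCC(=O)N1CCN(CCCOc2cc3c(Nc4ccc(F)c(Cl)c4)ncnc3cc2OC)CC1` gives 21.7% in this assay. Compound 2 `CCCCCCCCCOC(=O)CCC(=O)N1CCN(CCCOc2cc3c(Nc4ccc(F)c(Cl)c4)ncnc3cc2OC)CC1` gives 7.8%. Compound 3 `CCCCCCCCCCCCCOC(=O)CCC(=O)N1CCN(CCCOc2cc3c(Nc4ccc(F)c(Cl)c4)ncnc3cc2OC)CC1` gives 6.8%. The step of a number 13.9 percentage points lower from compound 1 to compound 2 (beyond the scatter) comes with the change (methyl in place of hydrogen on a saturated chain carbon, eight bonds along the chain from an oxygen next to a carbonyl group). The step of a number 14.9 percentage points lower from compound 1 to compound 3 (beyond the scatter) comes with the change (pentyl in place of hydrogen on a saturated chain carbon, eight bonds along the chain from an oxygen next to a carbonyl group). Between the two longer chains the step of a number 1 percentage points lower from compound 2 to compound 3 (within the scatter) is small, so compounds 2 and 3 cannot be ordered against each other on these numbers.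

Compound 4 `CCCCCCCCCCCCCCOC(=O)CCC(=O)N1CCN(CCCOc2cc3c(Nc4ccc(F)c(Cl)c4)ncnc3cc2OC)CC1` has not yet been measured in this assay. It differs from compound 3 by methyl in place of hydrogen on a saturated chain carbon, ten or more bonds along the chain from an oxygen next to a carbonyl group. This is the same kind of change as that from compound 1 to compound 2, but not the same: the methyl enters at a different place along the chain in the two cases, as the two described differences show. The two cores on which the change is made differ by pentyl in place of hydrogen on a saturated chain carbon, eight bonds along the chain from an oxygen next to a carbonyl group.

The earlier step of this kind, a number 13.9 percentage points lower from compound 1 to compound 2 (beyond the scatter), was modest, but the further step a number 1 percentage points lower from compound 2 to compound 3 (within the scatter) stayed within the scatter, so for compound 4 the expected step is a number 0.8 percentage points lower from compound 3 to compound 4 (within the scatter), essentially flat, because the effect of compound 3 at 6.8% already leaves little room to fall. Compound 4 is estimated at 6%, with a range of 2% to 13%.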

Compound 4, a percentage reported as activity, at one concentration (the size of the read-out at that concentration, not a potency): 77.2%
The estimate for compound 4 lay 71.2 percentage points below the measured number, and the stated range ends below it.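

In this assay, the effect of adding methyl on a saturated chain carbon does not carry from the shorter chain to the longer one; the direction reverses: the same change on two cores in this assay, a number 13.9 percentage points lower (beyond the scatter) from compound 1 to compound 2 and a number 70.4 percentage points higher (beyond the scatter) from compound 3 to compound 4, 84.3 percentage points apart, beyond the scatter of two such steps The comparisons with the two shorter-chain compounds give the same picture, with a number 69.4 percentage points higher from compound 2 to compound 4 (beyond the scatter) and a number 55.5 percentage points higher from compound 1 to compound 4 (beyond the scatter), so the weaker effect of compound 4 is not confined to its comparison with compound 3: the same change on two cores in this assay, a number 14.9 percentage points lower (beyond the scatter) from compound 1 to compound 3 and a number 69.4 percentage points higher (beyond the scatter) from compound 2 to compound 4, 84.3 percentage points apart, beyond the scatter of two such steps In this series, then, the step of a number 70.4 percentage points higher from compound 3 to compound 4 (beyond the scatter) shows that the size and direction of a chain extension cannot be transferred from one chain length to another, but it does not show what produces the reversal, and a single concentration cannot show how potency changes across the series.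

The compounds shown leave open whether a longer chain than that of compound 4 would keep this weak effect, and how chains of intermediate length between compound 2 and compound 3 would behave. They also leave open whether the same abrupt change would appear with a branched chain, or with a carboxylic acid or an amine at the end of the chain.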